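The compounds below may be only part of what the source reports. "The series", "measured", "known", "first", "only" and "open" are said of these compounds alone.

In an ADME assay on L929 cells (Mus musculus) for cytotoxicity, read by resazurin assay, with a stated time of 72 h (on this read-out lower numbers stand for stronger inhibition and higher numbers for weaker inhibition), three compounds with a shared core have been measured: compound 1 `O=C(/C=C/c1ccc2c(c1)B(O)OC2)c1ccc(O)cc1`, compound 2 `Nc1ccc(C(=O)/C=C/c2ccc3c(c2)B(O)OC3)cc1` and compound 3 `O=C(/C=C/c1ccc2c(c1)B(O)OC2)c1cccs1`. Compound 1 gives > 10 ug/mL, which is a limit. Compound 2 gives > 10 ug/mL, also a limit. Compound 3 gives > 10 ug/mL, again a limit and not a number. Compound 3 therefore has no exact place in the series, and the overall picture is the limit of > 10 ug/mL in this assay, at which 3 of the 3 values shown sit.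

Compound 4 `Cn1cccc1C(=O)/C=C/c1ccc2c(c1)B(O)OC2` departs from compound 3 at one place: 1-methyl-1H-pyrrol-2-yl in place of thiophen-2-yl on a carbonyl carbon. Within the data shown here, the steps that bear on this change alter the same carbonyl carbon substituent. They are a step that the two limits leave unreadable from compound 1 to compound 3 and a step that the two limits leave unreadable from compound 2 to compound 3, so neither offers a size to carry over. The expectation for compound 4 rests on the limit of compound 3, > 10 ug/mL. The estimated step is a step that the limit leaves unreadable from compound 3 to compound 4, and no change in either direction is expected beyond the scatter. For compound 4 the expected value is 15 ug/mL, with an estimated range from 8 ug/mL to 40 ug/mL.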

Compound 4, half-maximal inhibitory concentration: > 10 ug/mL
Compound 4: only a limit was reported (the forecaster's own chance of this, stated with the estimate: 85%); the middle value lies beyond the limit too.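

In this assay compound 4 gives > 10 ug/mL as a limit and not a number. Among these compounds, no step between compound 4 and compound 1, compound 2 or compound 3 can be read. The compounds shown leave open whether the changes at the carbonyl carbon alter cytotoxicity at all, since the series stands at one limit: the limit of > 10 ug/mL in this assay, at which 4 of the 4 values shown sit.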